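The compounds below may be only part of what the source reports. "The series", "measured", "known", "first", "only" and "open" are said of these compounds alone.

Compound 1 `O=C(O)c1ccccc1-c1ccc(CCc2ncc(CC3CCCC3)[nH]2)cc1` gives 133 nM in an in vitro functional assay on cells for agonist activity at Bombesin receptor subtype-3 (Homo sapiens), read by luminescence and calcium flux; on this read-out higher numbers stand for an effect only at larger amounts of compound and lower numbers for an effect already at smaller amounts.
Compound 2 `O=C(O)c1ccccc1-c1ccc(CCc2ncc(Cc3ccccc3F)[nH]2)cc1` gives 177 nM in this assay.
Compound 3 `CC(C)(C)Cc1cnc(CCc2ccc(-c3ccccc3C(=O)O)cc2)[nH]1` gives 106 nM in this assay.

All three share one core and differ only in the group carried on a saturated chain carbon bound to an aromatic carbon. On the face of it compound 3 carries the smallest number, yet a 1.3-fold lower number from compound 1 to compound 3 (0.10 log units; within the scatter) and a 1.7-fold lower number from compound 2 to compound 3 (0.22 log units; within the scatter) both fall within the usual scatter of repeated measurements, so the three compounds cannot be told apart on these data; the same holds for a 1.3-fold higher number from compound 1 to compound 2 (0.12 log units; within the scatter).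

Compound 4 `O=C(O)c1ccccc1-c1ccc(CCc2ncc(CC3CC3)[nH]2)cc1` is the next member of the series and is not yet measured. Its difference from compound 3 is cyclopropyl in place of tert-butyl on a saturated chain carbon bound to an aromatic carbon. Among the measured compounds shown here, the steps that bear on this change are the three exchanges already seen at the same place, cyclopentyl to 2-fluorophenyl, cyclopentyl to tert-butyl and 2-fluorophenyl to tert-butyl, none of which moved the number beyond the scatter. Cyclopropyl itself is untested, and it is the smallest group tried at this position, so some caution is warranted. The expectation for compound 4 in this assay is a step of a 1.7-fold higher number from compound 3 to compound 4 (0.23 log units; within the scatter), not beyond the scatter, giving an estimated 180 nM with a range from 70 nM to 500 nM.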

Compound 4, half-maximal effective concentration: 1000 nM
Estimate against measurement, compound 4: 5.6-fold (0.74 log units) below; the whole stated range lies below it.
By their numbers in this assay, from the lowest: compounds 3, 1 and 2 (each within the scatter of the next); then compound 4.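

Cyclopentyl, 2-fluorophenyl and tert-butyl had all given numbers within the scatter of one another, which made this position look open to quite different groups, but cyclopropyl shows that it is not indifferent to the group it carries in this assay: the steps to compound 4 are all beyond the scatter (a 9.4-fold higher number from compound 3 to compound 4 (0.97 log units; beyond the scatter); a 7.5-fold higher number from compound 1 to compound 4 (0.88 log units; beyond the scatter); a 5.6-fold higher number from compound 2 to compound 4 (0.75 log units; beyond the scatter)). A ring in the group does not on its own set compound 4 apart, since compound 1 and compound 2 carry rings as well, and the change from neopentyl to cyclopropylmethyl is small on paper, with 3 heavy atoms entering where 4 leave. Nothing shown here gives a measured reason for this rise.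

Still open, from the compounds shown here alone, is whether the rise belongs to the three-membered ring or to the smaller group as such, a question that cyclobutyl or isopropyl at this place could help settle. The groups shown hold only carbon and hydrogen, apart from the fluorine of compound 2, so the effect of an amine or a hydroxyl group here also remains unknown.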